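Swapping bromo for chloro on a triazole scaffold

The source may hold more compounds than are shown below. What is called first, only, known or untested is meant among the compounds shown, and "the series" means these compounds.

Compound 1 `Clc1cccc(CSc2nnc(-c3ccncc3)n2-c2ccccc2)c1` and compound 2 `Brc1cccc(CSc2nnc(-c3ccncc3)n2-c2ccccc2)c1` share one core; compound 3 `O=C(CSc1nnc(-c2ccncc2)n1-c1ccccc1)N/N=C/c1ccc(Br)cc1` and compound 4 `O=C(CSc1nnc(-c2ccncc2)n1-c1ccccc1)N/N=C/c1ccc(Cl)cc1` share another, and the difference between the two cores is not broken down here. In a functional assay on HCT-116 cells (Homo sapiens) for inhibition, read by MTT assay, with a stated time of 48 h (a higher number here means a weaker inhibitor, a lower number a stronger inhibitor), compound 1 gives 9820 nM, compound 2 gives 8170 nM, and compound 3 gives 4500 nM. The change from compound 2 to compound 1 is chloro in place of bromo on an aromatic carbon, and it gave a 1.2-fold higher number from compound 2 to compound 1 (0.08 log units; within the scatter). The change from compound 3 to compound 4 is chloro in place of bromo on an aromatic carbon; it is the same kind of change, though here the halogen sits para to a large group rather than meta to one. Because compound 2 to compound 1 showed only a 1.2-fold higher number from compound 2 to compound 1 (0.08 log units; within the scatter), a similarly small step a 1.2-fold higher number from compound 3 to compound 4 (0.08 log units; within the scatter) is expected here. Compound 4 is therefore estimated at 5400 nM, most likely between 2700 nM and 11000 nM in this assay.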

Compound 4, half-maximal inhibitory concentration: 5740 nM
Estimate against measurement, compound 4: 1.1-fold (0.03 log units) below; the range from low to high includes it.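

In this assay, chloro in place of bromo gave a 1.3-fold higher number from compound 3 to compound 4 (0.11 log units; within the scatter), so on this second core the swap again stays within the scatter. Set beside the earlier step, the two results agree: the same change on two cores in this assay, a 1.2-fold higher number (0.08 log units; within the scatter) from compound 2 to compound 1 and a 1.3-fold higher number (0.11 log units; within the scatter) from compound 3 to compound 4, 1.1-fold (0.03 log units) apart, within the scatter of two such steps. For the compounds shown here, this shows that, for this one pair of halogens, the small step carried from one core to the other, but with only two pairs in a single cell assay, it does not show that the swap would stay as small on any further core, nor why it is small.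

On these data alone, whether fluoro, a methoxy group, an amine or a carboxylic acid in place of the halogen would give a similarly small step remains open. So does whether the swap would read the same way in other cell lines.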